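A few compounds are considered here, and "the series" means these few. Any claim that something is new, unique, unknown or untested is made for them only; others in the source may bear on it.

Measured compounds in an assay (Cricetulus griseus) for inhibition of aldehyde dehydrogenase, mitochondrial (Homo sapiens); a lower number here means a stronger inhibitor, a higher number a weaker inhibitor:
compound 1, `O=c1c(-c2ccc(O)cc2)coc2cc(OCCOCCOCCO)ccc12`, 40 nM
compound 2, `CCOc1ccc2c(=O)c(-c3ccc(O)cc3)coc2c1`, 80 nM
compound 3, `CCOC(=O)CCCCOc1ccc2c(=O)c(-c3ccc(O)cc3)coc2c1`, 240 nM

Compound 3 gives the highest number of the three in this assay; compound 2 sits nearest to it, a step of a 3.0-fold higher number from compound 2 to compound 3 (0.48 log units; beyond the scatter), and compound 1 furthest, a step of a 6.0-fold higher number from compound 1 to compound 3 (0.78 log units; beyond the scatter), both beyond the scatter. Between compound 1 and compound 2 the step is a 2.0-fold higher number from compound 1 to compound 2 (0.30 log units; within the scatter), within the scatter.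

Compound 4, `O=c1c(-c2ccc(O)cc2)coc2cc(OCCCCCCCCCCCCO)ccc12`, has not been measured. From compound 3 it differs by 8-hydroxyoctyl in place of ethoxycarbonyl on a saturated chain carbon, four bonds along the chain from an oxygen on an aromatic ring. The chain on the aromatic oxygen is thus made longer and ends in a hydroxyl, as it does in compound 1.

Within the data shown here, the steps that bear on this change are those in which the chain on the aromatic oxygen is varied: compound 1, whose chain ends in a hydroxyl, gives the lowest number, and replacing that chain end by an ethoxycarbonyl-bearing chain in compound 3 raised the number by a 6.0-fold higher number from compound 1 to compound 3 (0.78 log units; beyond the scatter). A chain again carrying a terminal hydroxyl is therefore expected to move the number back down, by a modest amount, with a 3.0-fold lower number from compound 3 to compound 4 (0.48 log units; beyond the scatter) expected. Compound 4 is accordingly estimated at 80 nM in this assay, between 25 nM and 250 nM.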

Compound 4, half-maximal inhibitory concentration: 1700 nM
Compound 4: middle estimate off by 21-fold (1.33 log units), on the low side; the whole stated range lies below it.
By their numbers in this assay, from the lowest: compounds 1 and 2 (each within the scatter of the next); then compound 3; then compound 4.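

In this assay the change to the 8-hydroxyoctyl group, a 7.1-fold higher number from compound 3 to compound 4 (0.85 log units; beyond the scatter) and leaves compound 4 with the highest number of the four, so a terminal hydroxyl on the chain at this position does not by itself bring the number down. Compound 1 also has a chain ending in a hydroxyl and gives 40 nM while compound 4 gives 1700 nM so among these compounds the chain end alone does not settle the number, and the rest of the chain must be taken into account as well. Nothing in the information available explains this rise.

The compounds shown leave open whether the higher number of compound 4 follows from the length of its chain or from the absence of the ether oxygens found in the chain of compound 1, since the two chains differ in both. A shorter hydroxyalkyl chain, a long chain of the same kind without the terminal hydroxyl, or one ending in a carboxylic acid or an amine would be needed to tell how far each of these features counts at this position.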